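A few compounds are considered here, and "the series" means these few. Any claim that something is new, unique, unknown or untested is made for them only; others in the source may bear on it.

In a functional assay on QGY cells (Homo sapiens) for cytotoxicity, read by MTT assay, with a stated time of 48 h (on this read-out lower numbers stand for stronger inhibition and higher numbers for weaker inhibition), three compounds have been measured so far. Compound 1 `COc1cc([C@@H]2C[C@]2(CO)C(=O)NCc2ccc(C)cc2)cc(OC)c1OC` gives 25100 nM there, compound 2 `COc1cc([C@H]2C[C@]2(CO)C(=O)Nc2ccccc2Cl)cc(OC)c1OC` gives 40700 nM there, and compound 3 `CCOC(=O)[C@]1(C(=O)NCc2ccc(C)cc2)C[C@H]1c1cc(OC)c(OC)c(OC)c1` gives 32100 nM there. Compound 3 comes from compound 1 through one change, ethoxycarbonyl in place of hydroxymethyl on a saturated ring carbon and that step gave a 1.3-fold higher number from compound 1 to compound 3 (0.11 log units; within the scatter) in the read-out. The difference between the cores of compound 1 and compound 2 is not broken down here. Compound 4 `CCOC(=O)[C@]1(C(=O)Nc2ccccc2Cl)C[C@@H]1c1cc(OC)c(OC)c(OC)c1` is not yet measured; it comes from compound 2 through the same change, ethoxycarbonyl in place of hydroxymethyl on a saturated ring carbon at the same place. Because the earlier step of a 1.3-fold higher number from compound 1 to compound 3 (0.11 log units; within the scatter) stayed within the scatter, a step of similar size is expected now, a 1.2-fold higher number from compound 2 to compound 4 (0.09 log units; within the scatter) in the read-out. On that basis compound 4 is expected to give about 50000 nM in this assay when measured. The estimate for compound 4 is expected to fall between 25000 nM and 110000 nM in most repeats.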

Compound 4, half-maximal inhibitory concentration: 34700 nM
Estimate against measurement, compound 4: 1.4-fold (0.16 log units) above; the measured number falls inside the stated range.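

In this assay, putting ethoxycarbonyl in place of hydroxymethyl on a saturated ring carbon gave a 1.2-fold lower number from compound 2 to compound 4 (0.07 log units; within the scatter). Set beside the earlier step, the change carries over from one core to the other with no difference that can be told from the usual scatter: the same change on two cores in this assay, a 1.3-fold higher number (0.11 log units; within the scatter) from compound 1 to compound 3 and a 1.2-fold lower number (0.07 log units; within the scatter) from compound 2 to compound 4, 1.5-fold (0.18 log units) apart, within the scatter of two such steps This shows only that the swap left the read-out within the scatter on these two cores; it does not show that the swap would do so on a third core, nor does it explain why.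

The compounds shown leave open whether a carboxylic acid or a longer ester such as propoxycarbonyl on that saturated ring carbon would give a step beyond the scatter. They also leave open how this change behaves on other cell lines.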